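Trifluoromethylphenyl in Place of Fluorophenyl

The source may report more compounds than this note shows. Statements on the series, on what has been measured and on what is new or still open speak of the compounds shown alone.

Compound 2 `Oc1cccc(-c2cc(-c3cccc(F)c3)cc(-c3ccccc3O)n2)c1` sits at the limit of a functional assay on HeLa cells (Homo sapiens) for inhibition; on this read-out lower numbers stand for stronger inhibition and higher numbers for weaker inhibition: in this assay compound 2 gives > 50000 nM, which is a limit of the assay rather than a number. Compound 1 `Oc1ccccc1-c1cc(-c2cccc(F)c2)cc(-c2ccccc2O)n1` likewise reaches only the limit, giving > 50000 nM in this assay. Compound 3 `Oc1ccc(-c2cc(-c3cccc(F)c3)cc(-c3cccc(O)c3)n2)cc1` gives 14200 nM in this assay. The step that the two limits leave unreadable from compound 1 to compound 2 cannot be read, and the step of an at least 3.5-fold lower number from compound 2 to compound 3 (0.54 log units; beyond the scatter) concerns a hydroxyphenyl group, not the fluorophenyl group. Compound 4 `Oc1cccc(-c2cc(-c3ccccc3C(F)(F)F)cc(-c3ccccc3O)n2)c1` carries 2-(trifluoromethyl)phenyl in place of 3-fluorophenyl on an aromatic carbon. For the measured compounds named here, no measured step touches this group, so no shift beyond the scatter in this assay is expected for compound 4. The expected step is a step that the limit leaves unreadable from compound 2 to compound 4. Compound 4 is therefore estimated at about 60000 nM, within 12000 nM to 300000 nM, and may again return only a limit.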

Compound 4, half-maximal inhibitory concentration: 16800 nM
For compound 4 the middle estimate is 3.6-fold (0.55 log units) above the measured one, and the stated range covers the measured number.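

For the compounds shown here, the position opposite the ring nitrogen, which no earlier step touched, turns out to respond to change: in this assay, 2-(trifluoromethyl)phenyl in place of 3-fluorophenyl gives an at least 2.9-fold lower number from compound 2 to compound 4 (0.47 log units; beyond the scatter). The full size of this step cannot be read, because compound 2 gives only a limit of the assay: the limit of > 50000 nM in this assay, at which 2 of the 4 values shown sit.

On these data alone, whether the step belongs to the trifluoromethyl group itself or to where it sits on the phenyl ring stays open. Also open, as far as these compounds go, is what an amine or a carboxylic acid on that ring would do at this position.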